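2-Fluorophenyl in Place of 1-Methoxy-1-methylethyl in Compound 2

A few compounds are considered here, and "the series" means these few. Any claim that something is new, unique, unknown or untested is made for them only; others in the source may bear on it.

Compound 2 `COC(C)(C)[C@@H](O)C(=O)N1[C@H](C(=O)NCc2cc(Cl)ccc2-n2cnnn2)C[C@@H]2C[C@@H]21` gives 40 mL.min-1.g-1 in an ADME assay on liver for metabolic stability, with Liver microsome (Homo sapiens) as the target, read by LC-MS, using microsomes (on this read-out lower numbers stand for slow clearance and higher numbers for fast clearance), the highest of the two numbers reported, while compound 1 `O=C(NCc1cc(Cl)ccc1-n1cnnn1)[C@@H]1C[C@@H]2C[C@@H]2N1C(=O)[C@H](O)Cc1ccccn1` gives 17 mL.min-1.g-1. Compound 3 `COC(C)(C)[C@@H](O)C(=O)N1N=CC[C@H]1C(=O)NCc1cc(Cl)ccc1-n1cnnn1` is reported in this assay only as a limit, < 12 mL.min-1.g-1. For the measured compounds named here, the one measured step, a 2.4-fold higher number from compound 1 to compound 2 (0.37 log units; beyond the scatter), is modest. Compound 4 `O=C(NCc1cc(Cl)ccc1-n1cnnn1)[C@@H]1C[C@@H]2C[C@@H]2N1C(=O)[C@H](O)c1ccccc1F` differs from compound 2 by 2-fluorophenyl in place of 1-methoxy-1-methylethyl on a saturated chain carbon bound to a carbonyl carbon and an oxygen on a saturated carbon. No measured step covers a change of this kind at that position, so the single step shown gives no direction for it; it indicates only that swaps at this carbon have so far shifted clearance modestly. Compound 4 is therefore expected to sit near compound 2, with the estimated step of a 1.1-fold lower number from compound 2 to compound 4 (0.02 log units; within the scatter) within the scatter. The estimate for compound 4 is 38 mL.min-1.g-1, between 15 mL.min-1.g-1 and 95 mL.min-1.g-1.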

Compound 4, intrinsic clearance in microsomes: < 12 mL.min-1.g-1
Compound 4: only a limit was reported; the forecaster's own chance of this, stated with the estimate: 5%; middle value at least 3.1-fold (0.50 log units) from the limit.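

For the compounds shown here, at this saturated chain carbon, the swap to 2-fluorophenyl gives a clear fall in this assay, where the one earlier step had gone upward: the change is an at least 3.3-fold lower number from compound 2 to compound 4 (0.52 log units; beyond the scatter). Against (pyridin-2-yl)methyl, the same group gives an at least 1.4-fold lower number from compound 1 to compound 4 (0.15 log units; that floor lies within the scatter), a floor that settles no order between those two. The full size of either fall stays unread, as compound 4 is reported only as a limit: the limit of < 12 mL.min-1.g-1 in this assay, at which 2 of the 4 values shown sit.

The compounds shown leave open whether a plain phenyl, without the fluorine, would read the same, and how an amine on this carbon would behave.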